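The source may report more compounds than this note shows. Statements on the series, on what has been measured and on what is new or still open speak of the compounds shown alone.

Three compounds were examined in an assay on membranes from CHO cells for displacement of a labelled ligand from adenosine receptor A1 (Homo sapiens), read by scintillation counting, with a stated time of 60 min, tested at 1 uM; a lower number here means less inhibition, a higher number more inhibition at the concentration tested (going by the name of the read-out). Compound 1, `CCCOC(=O)C1=C(C)NC(=S)NC1c1ccco1`, gives 1% in this assay. Compound 2, `CC1=C(C(=O)OCC(C)C)C(c2ccco2)NC(=S)N1`, differs from compound 1 by methyl in place of hydrogen on a saturated chain carbon bound to two saturated chain carbons; in this assay compound 2 gives 7%, a step of a number 6 percentage points higher from compound 1 to compound 2 (within the scatter). Compound 3, `CCCOC(=O)C1=C(C)N(C)C(=O)NC1c1ccco1`, gives 3% in this assay. The difference between the core of compound 3 and the core of compound 1 is not broken down here, and the values of compound 1 and compound 3 lie within the scatter of each other, as do those of compound 2 and compound 3.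

Compound 4, `CC1=C(C(=O)OCC(C)C)C(c2ccco2)NC(=O)N1C`, has not yet been measured. It differs from compound 3 by methyl in place of hydrogen on a saturated chain carbon bound to two saturated chain carbons, the same change as that from compound 1 to compound 2, at a place described in the same words. The expected step of a number 3 percentage points higher from compound 3 to compound 4 (within the scatter) rests on the measured step of a number 6 percentage points higher from compound 1 to compound 2 (within the scatter), which lay within the scatter. Compound 4 is accordingly expected to give about 6% in this assay, most likely between -4% and 16%.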

Compound 4, a percentage reported as inhibition, at one concentration (the size of the read-out at that concentration, not a potency): 13%
The estimate for compound 4 lay 7 percentage points below the measured number; the measured number falls inside the stated range.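

In this assay, methyl in place of hydrogen on a saturated chain carbon bound to two saturated chain carbons, the change from propoxy to isobutoxy, gives a number 10 percentage points higher from compound 3 to compound 4 (within the scatter). Set beside the earlier step, the change reads alike on both cores: the same change on two cores in this assay, a number 6 percentage points higher (within the scatter) from compound 1 to compound 2 and a number 10 percentage points higher (within the scatter) from compound 3 to compound 4, 4 percentage points apart, within the scatter of two such steps. This shows that the two pairs give no sign of the core altering the outcome of this change, but it does not show that the change itself has a real effect in this assay, since neither step lies beyond the scatter, and two pairs say nothing about any further core.

The compounds shown carry only propoxy and isobutoxy at this place, which leaves open how a longer chain such as hexyloxy, or a chain ending in an amine or a carboxylic acid, would read in this assay. All the numbers also come from a single concentration, so the potency of these compounds remains open.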